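A few compounds are considered here, and "the series" means these few. Any claim that something is new, unique, unknown or untested is made for them only; others in the source may bear on it.

Measured compounds
- Compound 1, `NC(=O)c1ccc(C(=O)Nc2cc(-c3ccccc3)nn2-c2ccccc2)cc1`: in an assay on HEK293 cells for displacement of a labelled ligand from metabotropic glutamate receptor 5 (Rattus norvegicus) (on this read-out lower numbers stand for stronger inhibition and higher numbers for weaker inhibition), compound 1 gives > 10000 nM; this is a limit of the assay, not a number.
- Compound 2, `O=C(O)c1ccc(C(=O)Nc2cc(-c3ccccc3)nn2-c2ccccc2)cc1`: in this assay compound 2 gives > 10000 nM; this too is a limit of the assay.
- Compound 3, `O=C(Nc1cc(-c2ccccc2)nn1-c1ccccc1)c1ccc(Cl)c(Cl)c1`: in this assay compound 3 gives 160 nM.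

Within the data shown here, compound 3 carries the only number in the set; the other two values sit at the limit of > 10000 nM in this assay, at which 2 of the 3 values shown sit. The step from compound 1 to compound 3 is an at least 62-fold lower number from compound 1 to compound 3 (1.79 log units; beyond the scatter), and that from compound 2 to compound 3 is an at least 62-fold lower number from compound 2 to compound 3 (1.79 log units; beyond the scatter); the step from compound 1 to compound 2 is a step that the two limits leave unreadable from compound 1 to compound 2.

Compound 4, `O=C(CC1CCCC1)Nc1cc(-c2ccccc2)nn1-c1ccccc1`, is not yet measured. The change from compound 3 is cyclopentylmethyl in place of 3,4-dichlorophenyl on a carbonyl carbon. Both readable steps concern the same carbonyl carbon, but each swaps a substituted phenyl for another substituted phenyl; none exchanges an aromatic ring for a non-aromatic one, so they give only loose guidance. The two steps show that this position governs large swings, so a sizable move is plausible. A weaker result than compound 3 is expected for compound 4, with a 6.3-fold higher number from compound 3 to compound 4 (0.80 log units; beyond the scatter) as the estimated step. The expected value for compound 4 in this assay is 1000 nM, with a range from 250 nM to 5000 nM.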

Compound 4, inhibition constant: > 10000 nM
Compound 4 ended at the assay's limit (the forecaster's own chance of this, stated with the estimate: 20%); middle value at least 10-fold (1.00 log units) away from the limit.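

In this assay, among these compounds, the exchange of 3,4-dichlorophenyl for cyclopentylmethyl on the carbonyl carbon gives an at least 62-fold higher number from compound 3 to compound 4 (1.79 log units; beyond the scatter), and this is the first readable step that replaces the aromatic ring with a non-aromatic one. Cyclopentylmethyl has 0 hydrogen-bond donors, 0 hydrogen-bond acceptors and no net charge, so reaching the limit at this position does not require a carbamoyl or carboxy group like those of compound 1 and compound 2. The steps joining compound 4 to compound 1 and compound 2 run from limit to limit and cannot be read, and compound 3 remains the only compound with a number: the limit of > 10000 nM in this assay, at which 3 of the 4 values shown sit.

This single change removes both chlorine atoms and the aromatic ring, and it also alters the ring size, so the compounds shown do not separate the contributions of these features. An unsubstituted phenyl, a 4-chlorophenyl or a cyclohexyl group on the same carbonyl carbon would help to separate them, and would also test whether any non-aromatic group can give a readable number here.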